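Solubility notes: side-chain change on compound 2

The source may report more compounds than this note shows. Statements on the series, on what has been measured and on what is new or still open speak of the compounds shown alone.

- compound 1 `CCc1cccc(CC)c1NC(=O)c1cc(-c2nc(Nc3ccc(N4CCC(N5CCN(C)CC5)CC4)cc3OC)nc3[nH]ccc23)n(C)n1`: 18000 nM
- compound 2 `CCc1cccc(CC)c1N1CCn2cc(-c3nc(Nc4ccc(N5CCC(N6CCN(C)CC6)CC5)cc4OC)nc4[nH]ccc34)cc2C1=O`: 6000 nM

In a physicochemical assay for solubility, read by HPLC, in phosphate buffer, measured as kinetic solubility, with a stated time of 24 h, at pH 7.4, tested at 200 uM (a lower number here means a less soluble compound, a higher number a more soluble compound), compound 2 gives 6000 nM, the lower of the two numbers, and compound 1 gives 18000 nM. The gap between these two compounds lies beyond the scatter. Compound 3 `CCc1cccc(CC)c1N1CCn2cc(-c3nc(Nc4ccc(N5CCC(C(=O)N(C)CCN(C)C)CC5)cc4OC)nc4[nH]ccc34)cc2C1=O` carries (2-(dimethylamino)ethyl)(methyl)carbamoyl in place of 4-methylpiperazin-1-yl on a saturated ring carbon. For the measured compounds named here, no measured pair differs in one place, and no measured step informs this change. In this assay the expected result is a 1.3-fold higher number from compound 2 to compound 3 (0.12 log units; within the scatter), an estimated step not beyond the scatter. For compound 3 the estimated value is 8000 nM, with an expected range of 2500 nM to 26000 nM.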

Compound 3, solubility: 125000 nM
For compound 3 the middle estimate is 16-fold (1.19 log units) below the measured one; measured number above the stated range.
By their numbers in this assay, from the lowest: compound 2; then compound 1; then compound 3.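

In this assay, the saturated ring carbon proves a sensitive place in the series: (2-(dimethylamino)ethyl)(methyl)carbamoyl in place of 4-methylpiperazin-1-yl gives a 21-fold higher number from compound 2 to compound 3 (1.32 log units; beyond the scatter). The step comes with a ring lost and a carbonyl gained, while the hydrogen-bond donor and acceptor counts stay the same. No measurement shown accounts for the step.

The compounds shown do not separate the loss of the ring from the gain of the carbonyl. An open-chain amine without the carbonyl on the same ring carbon would bear on that question.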